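Fluorine position on the pendant fluorophenyl: compound 3 to compound 4

The source may hold more compounds than are shown below. What is called first, only, known or untested is meant among the compounds shown, and "the series" means these compounds.

Compound 3 `COc1cc2c(Oc3ccc(NC(=O)c4cc(-c5ccc(F)cc5)ccn4)cc3F)ccnc2cc1OCCCN1CCCC1` gives 1780 nM in a functional assay on U-87MG ATCC cells (Homo sapiens) for cytotoxicity, read by MTT assay, with a stated time of 72 h; a lower number here means a stronger inhibitor, a higher number a weaker inhibitor. Among the numbers available in this assay it stands as the higher of two: the nearest neighbour is compound 1 `COc1cc2c(Oc3ccc(NC(=O)c4cc(-c5ccccc5)ccn4)cc3F)ccnc2cc1OCCCN1CCCC1`, which in this assay gives 1010 nM, and the step of a 1.8-fold higher number from compound 1 to compound 3 (0.25 log units; within the scatter) lies within the scatter. Compound 2 `COc1cc2c(Oc3ccc(NC(=O)c4cc(-c5ccccc5C)ccn4)cc3F)ccnc2cc1OCCCN1CCCC1`, which carries a methyl on the same ring, has in this assay the entry "not determined" (no result reported), so no result exists for it and nothing can be said of it.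

The next member, compound 4 `COc1cc2c(Oc3ccc(NC(=O)c4cc(-c5ccccc5F)ccn4)cc3F)ccnc2cc1OCCCN1CCCC1`, differs from compound 3 by 2-fluorophenyl in place of 4-fluorophenyl on an aromatic carbon. For the measured compounds named here, only one measured step bears on this change: a 1.8-fold higher number from compound 1 to compound 3 (0.25 log units; within the scatter), which puts a fluorine onto the 4-fluorophenyl ring where compound 1 has none, and that step stays within the scatter. Going by the values given here, no measured pair shows what moving the fluorine from one position of that ring to another does, and no pair shows any substituent at the position that the 2-fluorophenyl group occupies. Among the compounds with values here, with a single within-scatter step as the only guide, the expectation for this assay is no movement beyond the scatter.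

Compound 4 is therefore estimated at 1500 nM, with a range of 600 nM to 3800 nM, and the step of a 1.2-fold lower number from compound 3 to compound 4 (0.07 log units; within the scatter) is expected to remain within the scatter.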

Compound 4, half-maximal inhibitory concentration: 610 nM
The estimate for compound 4 lay 2.5-fold (0.39 log units) above the measured number, and the stated range covers the measured number.
By their numbers in this assay, from the lowest: compounds 4, 1 and 3 (each within the scatter of the next, the first and the last beyond it).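

In this assay, for the compounds shown here, the place of the fluorine on the pendant ring is the first change in this set to pass beyond the scatter (a 2.9-fold lower number from compound 3 to compound 4 (0.47 log units; beyond the scatter)), with 2-fluorophenyl in place of 4-fluorophenyl. Each fluorinated compound still stays within the scatter of the unfluorinated compound 1 (a 1.7-fold lower number from compound 1 to compound 4 (0.22 log units; within the scatter); a 1.8-fold higher number from compound 1 to compound 3 (0.25 log units; within the scatter)), so the effect of position appears only when the two isomers are compared directly, and adding fluorine alone shows no clear change in either case. No available data explain why the two fluorine positions differ in this cytotoxicity read-out.

As far as these compounds go, it remains open whether the difference belongs to fluorine itself or would also appear with another group in the place held by the fluorine of 2-fluorophenyl, since compound 2, with a methyl on that ring, offers no number for comparison. A chlorine, a methoxy group or an amine on the pendant ring could separate these readings, and the compounds shown cannot say whether the step between the isomers extends beyond this one cell line.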